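The source may report more compounds than this note shows. Statements on the series, on what has been measured and on what is new or still open speak of the compounds shown alone.

In a functional assay on PANC-1 cells (Homo sapiens) for inhibition, read by MTT assay, with a stated time of 24 h, tested at 10 uM (on this read-out lower numbers stand for less inhibition and higher numbers for more inhibition at the one concentration tested (going by the name of the read-out)), three compounds have been measured:

Compound 1 `CCOc1cc(=O)n(CCCO)c2c1CC(C/C=C(\C)CCC=C(C)C)C(C)(C)C2`: 0.8%
Compound 2 `CC(C)=CCC/C(C)=C/CC1Cc2c(OCc3ccccc3)cc(=O)n(CCCO)c2CC1(C)C`: 1.5%
Compound 3 `CC(C)=CCC/C(C)=C/CC1Cc2c(OCCCNS(=O)(=O)c3ccc(Br)cc3)cc(=O)n(CCCO)c2CC1(C)C`: 0%

Compound 3 carries the lowest of the three numbers, yet its gaps to compound 1 and compound 2 both lie within the scatter, so the three stand together. Compound 4 `CC(C)=CCC/C(C)=C/CC1Cc2c(OCCCNC(=O)c3ccco3)cc(=O)n(CCCO)c2CC1(C)C` differs from compound 3 in one place: (furan-2-yl)carbonyl in place of (4-bromophenyl)sulfonyl on an amine nitrogen. The measured steps that bear on this end of the chain are a number 0.8 percentage points lower from compound 1 to compound 3 (within the scatter) and a number 0.7 percentage points higher from compound 1 to compound 2 (within the scatter), both within the scatter, so changes at the chain attached to the aromatic oxygen have left the read-out flat so far. Within the data shown here, no measured pair compares the two groups of this change directly. Compound 4 is therefore expected to show a number 1 percentage points higher from compound 3 to compound 4 (within the scatter), that is a step of no size beyond the scatter. Compound 4 is estimated at 1%, with a range from 0% to 8%.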

Compound 4, a percentage reported as inhibition, at one concentration (the size of the read-out at that concentration, not a potency): 2.8%
Compound 4: the middle estimate sits 1.8 percentage points below what was measured, within the range that was stated.
By their numbers in this assay, from the lowest: compounds 3, 1, 2 and 4 (each within the scatter of the next).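

In this assay, the exchange at the amine nitrogen gives a number 2.8 percentage points higher from compound 3 to compound 4 (within the scatter), so (furan-2-yl)carbonyl and (4-bromophenyl)sulfonyl cannot be told apart at this position. The wider changes on the chain at the aromatic oxygen, a number 1.3 percentage points higher from compound 2 to compound 4 (within the scatter) and a number 2 percentage points higher from compound 1 to compound 4 (within the scatter), also stay within the scatter, and all four compounds remain together. No supporting measurement bears on this result. As far as these compounds go, what stays open is whether an amine or a carboxylic acid at the end of this chain, or a longer chain, would move the read-out beyond the scatter.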